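From Methylamino to Propargylamino on a Shared Core

The source may report more compounds than this note shows. Statements on the series, on what has been measured and on what is new or still open speak of the compounds shown alone.

In an assay on CHO cells for displacement of a labelled ligand from adenosine receptor A1 (Homo sapiens), read by scintillation counting, with a stated time of 1 h, tested at 1 uM (a higher number here means more inhibition at the concentration tested (going by the name of the read-out), a lower number less inhibition), compound 1 `CCCC(=O)Nc1ncc(-c2cccc(Cl)c2)c(-c2ccccc2)n1` reaches > 80%, which is a limit of the assay rather than a number. Compound 2 `O=C(Nc1ncc(-c2cccc(Cl)c2)c(-c2ccccc2)n1)C1CCCC1` gives 47% in this assay. Compound 3 `CNc1ncc(-c2cccc(Cl)c2)c(-c2ccccc2)n1` gives 75%, the higher of the two plain numbers, and its nearest neighbour is compound 2. The measured steps all concern the group on the ring nitrogen: the step of a number at least 33 percentage points lower from compound 1 to compound 2 (beyond the scatter) came with cyclopentyl in place of propyl on a carbonyl carbon, the step of a number 28 percentage points higher from compound 2 to compound 3 (beyond the scatter) with methyl in place of cyclopentylcarbonyl, and the step of a number at least 5 percentage points lower from compound 1 to compound 3 (that floor lies within the scatter) with methyl in place of propylcarbonyl. Compound 4 `C#CCNc1ncc(-c2cccc(Cl)c2)c(-c2ccccc2)n1` is the next member; it differs from compound 3 by ethynyl in place of hydrogen on a saturated chain carbon bound to a nitrogen on an aromatic ring. The measured steps exchanged acyl groups and a methyl, whereas this change keeps the amine and adds only a short chain, so the step of a number 3 percentage points lower from compound 3 to compound 4 (within the scatter) is expected to stay within the scatter. Compound 4 is therefore estimated at 72%, between 50% and 88%.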

Compound 4, a percentage reported as inhibition, at one concentration (the size of the read-out at that concentration, not a potency): 76%
Estimate against measurement, compound 4: 4 percentage points below; the measured number falls inside the stated range.
By their numbers in this assay, from the lowest: compound 2; then compounds 3 and 4 (each within the scatter of the next). At a limit, above all of these: compound 1.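

Extending methyl to propargyl on the nitrogen on the aromatic ring leaves the reading in this assay unresolved from that of the smaller group: ethynyl in place of hydrogen gives a number 1 percentage points higher from compound 3 to compound 4 (within the scatter). The propargyl amine also stands clear of the cyclopentylcarbonyl group, with a number 29 percentage points higher from compound 2 to compound 4 (beyond the scatter), so this gap is not confined to methyl. Against compound 1, whose value is a limit and not a number, the step is a number at least 4 percentage points lower from compound 1 to compound 4 (that floor lies within the scatter), which leaves their order unsettled: the limit of > 80% in this assay, at which 1 of the 4 values shown sits.

On these data alone, whether a longer chain such as butyl, or a chain ending in a carboxylic acid, would hold the reading at this nitrogen remains open. A reading at one concentration also gives no potency for compound 3 or compound 4, so a difference between them could still lie hidden.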